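From ethynyl to methoxy at the assay limit

This account rests on a few compounds, and the source may have more. Where it says the series, first, only, none or still open, it means among the compounds named here.

Values in a functional assay on A549 cells (Homo sapiens) for antiproliferative activity, read by MTT assay, with a stated time of 72 h; a higher number here means a weaker inhibitor, a lower number a stronger inhibitor:
Compound 1 `C#Cc1cccc(Nc2ncnc3cc(OC)c(OCCCN4CCNCCNCCNCC4)cc23)c1`: 28600 nM
Compound 2 `COc1cc2ncnc(Nc3cccc(C(F)(F)F)c3)c2cc1OCCCN1CCNCCNCCNCC1`: 15700 nM
Compound 3 `C#Cc1cccc(Nc2ncnc3cc(OC)c(OCCCN4CCNCCNCC4)cc23)c1`: > 50000 nM (a limit)

Compound 3 stands at > 50000 nM, which is a limit of the assay and not a number. Compound 4 `COc1cccc(Nc2ncnc3cc(OC)c(OCCCN4CCNCCNCC4)cc23)c1` carries methoxy in place of ethynyl on an aromatic carbon, meta to a large group: methoxy in place of ethynyl on an aromatic carbon. The nearest measured exchange is a 1.8-fold lower number from compound 1 to compound 2 (0.26 log units; within the scatter), with trifluoromethyl in place of ethynyl. The other measured step, an at least 1.7-fold higher number from compound 1 to compound 3 (0.24 log units; that floor lies within the scatter), alters the saturated ring and leaves that aromatic carbon unchanged. No step beyond the scatter is therefore expected in this assay, although the starting point is only a limit. The expected step is a number no higher from compound 3 to compound 4 (the limit leaves the size open). For compound 4 the estimated value is 50000 nM, with an expected range of 25000 nM to 100000 nM.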

Compound 4, half-maximal inhibitory concentration: > 50000 nM
Compound 4 gave a limit, no number; the forecaster's own chance of this, stated with the estimate: 65%; the middle value lies on the limit itself.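

No step can be read from compound 3 to compound 4 in this assay, since both compounds sit at the same limit: the limit of > 50000 nM in this assay, at which 2 of the 4 values shown sit.

Going by these compounds, whether methoxy in place of ethynyl changes activity at all remains open.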